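This account rests on a few compounds, and the source may have more. Where it says the series, first, only, none or still open, it means among the compounds named here.

Within the data shown here, only two compounds sharing one core have been measured so far in a functional assay on HCT-116 cells (Homo sapiens) for inhibition, read by colorimetric assay, with a stated time of 3 days; on this read-out lower numbers stand for stronger inhibition and higher numbers for weaker inhibition. Compound 1 `O=C(CCCCCCNC(=O)C(O)(O)C(F)(F)F)Nc1ccncc1` gives 6670 nM there, while compound 2 `O=C(CCCCCCNC(=O)C(O)(O)C(F)(F)F)Nc1c(F)cc(F)cc1F` gives 22200 nM, the higher of the two numbers and so the weaker inhibition. Among the measured compounds shown here, compound 3 `COc1cccc(NC(=O)CCCCCCNC(=O)C(O)(O)C(F)(F)F)c1` keeps the same core and changes only one group: 3-methoxyphenyl in place of 2,4,6-trifluorophenyl on an amide-type nitrogen. In words, it has 3-methoxyphenyl in place of 2,4,6-trifluorophenyl on an amide-type nitrogen.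

Just one measured step bears on this change, a 3.3-fold higher number from compound 1 to compound 2 (0.52 log units; beyond the scatter), and it is a modest step beyond the scatter. It involved the same position, with 2,4,6-trifluorophenyl in place of pyridin-4-yl, so the group at this nitrogen can shift the number by a modest amount. For the measured compounds named here, two compounds show no trend, and no measured compound carries 3-methoxyphenyl. Since compound 2 holds the higher number at 22200 nM, a move downward seems more likely than a further rise. Going by the values given here, the expected change is a 2.2-fold lower number from compound 2 to compound 3 (0.35 log units; beyond the scatter), smaller than the one measured step. For compound 3 the estimated value is 10000 nM, with an expected range from 3500 nM to 25000 nM.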

Compound 3, half-maximal inhibitory concentration: 6110 nM
Beside the measured number, compound 3's estimate is 1.6-fold (0.21 log units) above it; the range from low to high includes it.
By their numbers in this assay, from the lowest: compounds 3 and 1 (each within the scatter of the next); then compound 2.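

In this assay, among these compounds, the swap of 2,4,6-trifluorophenyl for 3-methoxyphenyl on the amide-type nitrogen gives a 3.6-fold lower number from compound 2 to compound 3 (0.56 log units; beyond the scatter) and so shows a step beyond the scatter in the downward direction, whereas the only earlier step at this position went upward. Comparing 3-methoxyphenyl with pyridin-4-yl gives a 1.1-fold lower number from compound 1 to compound 3 (0.04 log units; within the scatter) and so these two quite different groups cannot be told apart in this assay, while compound 2 alone stands apart, with its steps to both other compounds lying beyond the scatter. Nothing measured on these groups beyond the cell numbers themselves is available to explain how they differ.

Among the compounds shown here, with only three groups at this nitrogen, it remains open whether 2,4,6-trifluorophenyl is a lone exception or one end of a wider spread, and a plain phenyl or a ring carrying an amine would help to settle that. As far as these compounds go, all three compounds also share the same chain and the same trifluoromethyl end, so the effect of a longer chain, or of a different group at that end, remains unknown.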